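Phenylsulfonyl in place of a thiophen-2-yl carbonyl

This account rests on a few compounds, and the source may have more. Where it says the series, first, only, none or still open, it means among the compounds named here.

In a functional assay on MKN-45 cells (Homo sapiens) for cytotoxicity (a higher number here means a weaker inhibitor, a lower number a stronger inhibitor), compound 1 `COc1ccc(S(=O)(=O)N2CCc3cccc(NC(=O)c4cccs4)c32)cc1` gives 31 nM, the lowest number of the three measured compounds. Compound 3 `COc1ccc(S(=O)(=O)N2CCc3cc(Br)cc(NC(=O)c4ccco4)c32)cc1` gives 78 nM, a gap beyond the usual scatter, and it differs from compound 1 in more than one place. Compound 2 `COc1ccc(S(=O)(=O)N2CCc3cccc(NC(=O)Oc4ccccc4)c32)cc1` reads > 10000 nM, which is a limit of the assay and not a number.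

Among the compounds with values here, only one measured step changes a single place: an at least 320-fold higher number from compound 1 to compound 2 (2.50 log units; beyond the scatter). It is large, and it alters the same part of the molecule that differs in compound 4 `COc1ccc(S(=O)(=O)N2CCc3cccc(NS(=O)(=O)c4ccccc4)c32)cc1`. There the change goes further: phenylsulfonyl in place of (thiophen-2-yl)carbonyl on a nitrogen on an aromatic ring. Within the data shown here, the carbonyl itself is gone, and no measured compound shows what that alone does. Among the measured compounds shown here, with compound 2 and its step of an at least 320-fold higher number from compound 1 to compound 2 (2.50 log units; beyond the scatter) as the only guide, a clear rise in the number is expected, though probably a smaller one, and its size is very uncertain. The estimated step is a 26-fold higher number from compound 1 to compound 4 (1.41 log units; beyond the scatter). For compound 4 the expected value is 800 nM, with an estimated range from 60 nM to 10000 nM.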

Compound 4, half-maximal inhibitory concentration: 562 nM
The estimate for compound 4 lay 1.4-fold (0.15 log units) above the measured number, and the stated range covers the measured number.
By their numbers in this assay, from the lowest: compound 1; then compound 3; then compound 4. At a limit, above all of these: compound 2.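

Replacing the (thiophen-2-yl)carbonyl on this nitrogen with phenylsulfonyl gives an 18-fold higher number from compound 1 to compound 4 (1.26 log units; beyond the scatter) in this assay, so the carbonyl-linked thiophene remains clearly the better of these two groups. Losing the carbonyl does not by itself abolish activity, however, and keeping it does not guarantee activity: phenylsulfonyl in place of phenoxycarbonyl gives an at least 17-fold lower number from compound 2 to compound 4 (1.25 log units; beyond the scatter), which shows that a group on this nitrogen can lack the carbonyl and still read far better than compound 2. Compound 2 reads > 10000 nM, which is a limit of the assay and not a number: the limit of > 10000 nM in this assay, at which 1 of the 4 values shown sits.

Compound 4 changes both the ring and the linking group, and the compounds shown do not separate these two changes. A thiophen-2-ylsulfonyl group or a benzoyl group on the same nitrogen would show how much of the step belongs to each.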